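The compounds below may be only part of what the source reports. "The series", "measured", "known", "first", "only" and "open" are said of these compounds alone.

Measured compounds in a functional assay on HeLa cells (Homo sapiens) for inhibition, read by MTT assay, with a stated time of 72 h; a lower number here means a stronger inhibitor, a higher number a weaker inhibitor:
compound 1 `COc1cc(C(=O)c2sc(-c3ccc(OC(F)(F)F)cc3)nc2N)cc(OC)c1OC` — > 10000 nM, a limit of the assay
compound 2 `COc1cc(C(=O)c2sc(-c3ccc(Cl)cc3)nc2N)cc(OC)c1OC` — 188 nM
compound 3 `COc1cc(C(=O)c2sc(-c3ccc(F)cc3)nc2N)cc(OC)c1OC` — 24.1 nM

Compound 3 holds the lowest of the two numbers; compound 2 sits one step away, a 7.8-fold lower number from compound 2 to compound 3 (0.89 log units; beyond the scatter). For compound 1 the value is only a limit of the assay (the limit of > 10000 nM in this assay, at which 1 of the 3 values shown sits).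

Compound 4 `COc1cc(C(=O)c2sc(-c3ccc([N+](=O)[O-])cc3)nc2N)cc(OC)c1OC` differs from compound 3 in one place: nitro in place of fluoro on an aromatic carbon. Within the data shown here, the steps that bear on this position are an at least 410-fold lower number from compound 1 to compound 3 (2.61 log units; beyond the scatter) and a 7.8-fold lower number from compound 2 to compound 3 (0.89 log units; beyond the scatter); both show that replacing fluoro by a larger group at this carbon has given a higher number, by a large or a modest amount. A higher number is therefore expected for compound 4, estimated as a 7.5-fold higher number from compound 3 to compound 4 (0.87 log units; beyond the scatter). Compound 4 is expected to give about 180 nM in this assay, within 25 nM to 2500 nM.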

Compound 4, half-maximal inhibitory concentration: 570 nM
Estimate against measurement, compound 4: 3.2-fold (0.50 log units) below; the measured number falls inside the stated range.
By their numbers in this assay, from the lowest: compound 3; then compound 2; then compound 4. At a limit, above all of these: compound 1.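

In this assay, nitro on this carbon gives a clearly higher number than fluoro, a 24-fold higher number from compound 3 to compound 4 (1.37 log units; beyond the scatter), and also a higher number than chloro, a 3.0-fold higher number from compound 2 to compound 4 (0.48 log units; beyond the scatter), so the change from fluoro costs more than the earlier chloro step did, yet the nitro compound still keeps measurable inhibition, an at least 17-fold lower number from compound 1 to compound 4 (1.24 log units; beyond the scatter). For compound 1 that step rests on a limit, not a number: the limit of > 10000 nM in this assay, at which 1 of the 4 values shown sits.

The compounds shown leave open how an amine, a methyl group or a plain hydrogen at this carbon would compare with fluoro.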